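The source may report more compounds than this note shows. Statements on the series, on what has been measured and on what is new or still open speak of the compounds shown alone.

Measured so far:
compound 1 `Fc1ccc(C2=CC3CNCC(C2)C3)cn1`, in an in vitro functional assay on SH-EP1 cells for agonist activity at Neuronal acetylcholine receptor; alpha4/beta2 (Homo sapiens), read by FLIPR and calcium flux (on this read-out higher numbers stand for an effect only at larger amounts of compound and lower numbers for an effect already at smaller amounts), compound 1 gives 85 nM
compound 2 `CC(C)Oc1cncc(C2=CC3CC(C2)CN(C)C3)c1`, in this assay compound 2 gives only a limit of the assay, > 10000 nM
compound 3 `Clc1ccc(C2=CC3CNCC(C2)C3)cn1`, in this assay compound 3 gives 54 nM

Compound 3 stands at the lowest of the two numbers; compound 1 is nearest with a number higher by a 1.6-fold lower number from compound 1 to compound 3 (0.20 log units; within the scatter), a step within the scatter. The remaining value, that of compound 2, is a limit of the assay, as noted in the limit of > 10000 nM in this assay, at which 1 of the 3 values shown sits.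

Compound 4 `C1=C(c2ccc(-c3ccccc3)nc2)CC2CNCC1C2` differs from compound 3 in one place: phenyl in place of chloro on an aromatic carbon.

Within the data shown here, only one measured step exists, that from compound 1 to compound 3, and it swaps one halogen for another on the same aromatic carbon; it is within the scatter and so carries little for a change in which a whole aromatic ring replaces a halogen. The step from compound 2 to any other compound is not a clean single change and ends at a limit, so it gives no measure of size either. The change to compound 4 is therefore without a close precedent among the measured compounds. Given that a group of this size at that position has not been tested in the series, the number for compound 4 is expected to move to larger amounts of compound rather than smaller, by an estimated 56-fold higher number from compound 3 to compound 4 (1.74 log units; beyond the scatter) in this assay, with a real chance that only a limit is returned. Compound 4 is estimated at 3000 nM in this assay, within 400 nM to 20000 nM.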

Compound 4, half-maximal effective concentration: > 10000 nM
Compound 4: a limit, no number; the forecaster's own chance of this, stated with the estimate: 35%; at least 3.3-fold (0.52 log units) between middle value and limit.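

In this assay, compound 4 returns a limit of the assay, not a number: the limit of > 10000 nM in this assay, at which 2 of the 4 values shown sit.

Replacing the halogen with phenyl gives an at least 180-fold higher number from compound 3 to compound 4 (2.26 log units; beyond the scatter), and likewise an at least 110-fold higher number from compound 1 to compound 4 (2.07 log units; beyond the scatter); both steps are large. The earlier exchange of fluoro for chloro on this aromatic carbon next to the ring nitrogen stayed within the scatter, so only now does this position show that the group placed on it can decide whether a number is obtained at all.

The compounds shown span only two halogens and a phenyl ring, so the point at which the number is lost stays open. Whether a methyl, a methoxy group or an amine on this carbon keeps a number close to those of the halogens is also unresolved, as is whether a phenyl ring carrying a hydroxyl group ends at the same limit.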